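The source may report more compounds than this note shows. Statements on the series, on what has been measured and on what is new or still open speak of the compounds shown alone.

The measured compounds:
compound 1 `CCCOc1ccc2cc(C(=O)NCCO)c(=O)oc2c1`; in a functional assay on HCT-116 cells (Homo sapiens) for cytotoxicity, read by MTT assay, with a stated time of 72 h (a lower number here means a stronger inhibitor, a higher number a weaker inhibitor), compound 1 gives > 100000 nM, a limit of the assay.
compound 2 `CCN(CC)c1ccc2cc(C(=O)NN)c(=O)oc2c1`; in this assay compound 2 gives 3360 nM.
compound 3 `CCOc1ccc2cc(C(=O)NN)c(=O)oc2c1`; in this assay compound 3 gives > 100000 nM, which is again a limit of the assay and not a number.

Compound 3 thus stands at the top of the scale; no number is known for it, and two of the three values shown sit at that limit (the limit of > 100000 nM in this assay, at which 2 of the 3 values shown sit). Compound 2 alone gives a number. Going by the values given here, the only measured step that touches compound 3 is an at least 29-fold higher number from compound 2 to compound 3 (1.47 log units; beyond the scatter), where an ethoxy group takes the place of a diethylamino group on an aromatic carbon.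

Compound 4 `CCCOc1ccc2cc(C(=O)NN)c(=O)oc2c1` differs from compound 3 by methyl in place of hydrogen on a saturated chain carbon, two bonds along the chain from an oxygen on an aromatic ring. No measured step shows such a lengthening of the chain; the one step shown concerns a different position. Compound 1 also carries a propoxy group and also ends at the limit. With compound 3 already at the limit, no step beyond the scatter is expected, and the step from compound 3 to compound 4 is estimated as a step that the limit leaves unreadable from compound 3 to compound 4. Compound 4 is therefore expected to give about 150000 nM, within 50000 nM to 400000 nM, most likely reported only as a limit.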

Compound 4, half-maximal inhibitory concentration: 69800 nM
Compound 4: the middle estimate sits 2.1-fold (0.33 log units) above what was measured; low and high end bracket the measured number.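

In this assay compound 4 gives 69800 nM and so the propoxy group on the hydrazide yields the first actual number among the compounds shown that carry an alkoxy group rather than diethylamino. The large loss seen earlier with ethoxy in place of diethylamino also appears with propoxy in place of diethylamino, as the data show a 21-fold higher number from compound 2 to compound 4 (1.32 log units; beyond the scatter) and so lengthening ethoxy to propoxy does not bring compound 4 close to compound 2. The change from ethoxy to propoxy gives an at least 1.4-fold lower number from compound 3 to compound 4 (0.15 log units; that floor lies within the scatter) and the change from 2-hydroxyethyl to amino on the amide-type nitrogen gives an at least 1.4-fold lower number from compound 1 to compound 4 (0.15 log units; that floor lies within the scatter) and neither step can be read as more than a floor, because compound 3 and compound 1 both start from a limit and not from a number: the limit of > 100000 nM in this assay, at which 2 of the 4 values shown sit.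

The compounds shown leave open whether a longer chain such as butoxy, or a shorter one such as methoxy, would give a number on this scale, and how dimethylamino or a free amine would compare with diethylamino on the aromatic carbon. They also leave open what a 2-hydroxyethyl group on the amide-type nitrogen would give when diethylamino is present on the shared core.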